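Replacing a Pyrrolidine with a Chloroanilino Group

The source may hold more compounds than are shown below. What is called first, only, known or untested is meant among the compounds shown, and "the series" means these compounds.

Three measured compounds share one core and differ only in a single substituent on the (phenylcarbamoyl)amino group. Compound 1 `O=C(Nc1ccc(Cl)cc1)Nc1nc(Sc2c[nH]c3ccccc23)cc(N2CCCC2)n1` carries a chloro group, and in a functional assay on MDA-MB-231 cells (Homo sapiens) for inhibition, with a stated time of 72 h (on this read-out higher numbers stand for weaker inhibition and lower numbers for stronger inhibition), compound 1 gives 5850 nM. Compound 2 `O=C(Nc1ccccc1)Nc1nc(Sc2c[nH]c3ccccc23)cc(N2CCCC2)n1` has hydrogen in its place, and in this assay compound 2 gives 7890 nM. Compound 3 `COc1ccc(NC(=O)Nc2nc(Sc3c[nH]c4ccccc34)cc(N3CCCC3)n2)cc1` carries a methoxy group, and compound 3 gives 13100 nM. Among these three numbers compound 2 stands second highest: there is a 1.3-fold higher number from compound 1 to compound 2 (0.13 log units; within the scatter), and a 1.7-fold higher number from compound 2 to compound 3 (0.22 log units; within the scatter), while a 2.2-fold higher number from compound 1 to compound 3 (0.35 log units; beyond the scatter).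

Compound 4 `O=C(Nc1ccccc1)Nc1nc(Nc2ccc(Cl)cc2)cc(Sc2c[nH]c3ccccc23)n1` keeps the (phenylcarbamoyl)amino group of compound 2 unchanged but alters another position of the core: (4-chlorophenyl)amino in place of pyrrolidin-1-yl on an aromatic carbon. Going by the values given here, none of the measured steps touches this position; all three concern the substituent on the (phenylcarbamoyl)amino group, so they offer no guide to the direction or size of this change. With nothing to anchor it, compound 4 is expected to land near compound 2, and the estimated step is a 1.0-fold higher number from compound 2 to compound 4 (0.01 log units; within the scatter). The value for compound 4 is therefore estimated at 8000 nM, within a wide range from 2000 nM to 32000 nM.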

Compound 4, half-maximal inhibitory concentration: 10300 nM
The estimate for compound 4 lay 1.3-fold (0.11 log units) below the measured number; measured number inside the range.
By their numbers in this assay, from the lowest: compounds 1, 2, 4 and 3 (each within the scatter of the next, the first and the last beyond it).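

In this assay, the change at this position reads as a 1.3-fold higher number from compound 2 to compound 4 (0.12 log units; within the scatter), so the two compounds cannot be told apart here. Going by these compounds alone, this is the first view of this position, and it shows that pyrrolidin-1-yl, a five-membered non-aromatic ring, can give way to (4-chlorophenyl)amino, which brings a six-membered aromatic ring and a hydrogen-bond donor, without a shift beyond the usual scatter. Nothing available explains why the two groups read alike.

The compounds shown leave open whether the chloro group on the entering ring matters in its own right, or whether a plain phenylamino group would read the same. Also open, on these data alone, is how a morpholin-4-yl group, an open-chain amine such as dimethylamino, or a carboxylic acid on the entering ring would read at this position.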